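Amide substituent swap on the shared core

This account rests on a few compounds, and the source may have more. Where it says the series, first, only, none or still open, it means among the compounds named here.

Three compounds share one core: compound 1 `COc1ccc2c(=O)c(/C=C/C(=O)Nc3cccc(C)c3)coc2c1`, compound 2 `COc1cccc(NC(=O)/C=C/c2coc3cc(OC)ccc3c2=O)c1` and compound 3 `COc1ccc(CNC(=O)/C=C/c2coc3cc(OC)ccc3c2=O)cc1`. In a functional assay on Huh-7 cells (Homo sapiens) for inhibition, read by MTT assay, with a stated time of 48 h (a higher number here means a weaker inhibitor, a lower number a stronger inhibitor), compound 1 gives 15500 nM, compound 2 gives 11100 nM and compound 3 gives 7570 nM, the lowest of the three numbers, though its gap to compound 2 lies within the scatter.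

Compound 4 `COc1ccc2c(=O)c(/C=C/C(=O)Nc3ccccc3OC)coc2c1` differs from compound 3 by 2-methoxyphenyl in place of 4-methoxybenzyl on an amide-type nitrogen. For the measured compounds named here, the steps that bear on this are a 2.0-fold lower number from compound 1 to compound 3 (0.31 log units; beyond the scatter) and a 1.5-fold lower number from compound 2 to compound 3 (0.17 log units; within the scatter), both moving toward the 4-methoxybenzyl group; compound 4 moves back to an aryl amide. A modest rise in the number, at most near the edge of the scatter, is therefore expected, a 1.4-fold higher number from compound 3 to compound 4 (0.14 log units; within the scatter). Compound 4 is estimated at 10500 nM, within 5000 nM to 22000 nM.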

Compound 4, half-maximal inhibitory concentration: 32300 nM
Estimate against measurement, compound 4: 3.1-fold (0.49 log units) below, and the stated range ends below it.
By their numbers in this assay, from the lowest: compounds 3, 2 and 1 (each within the scatter of the next, the first and the last beyond it); then compound 4.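

On the amide-type nitrogen, moving the methoxy group around the aryl ring matters more than any earlier change: going from 3-methoxyphenyl to 2-methoxyphenyl gives (a 2.9-fold higher number from compound 2 to compound 4 (0.46 log units; beyond the scatter)). The 2-methoxyphenyl group also loses to 3-methylphenyl (a 2.1-fold higher number from compound 1 to compound 4 (0.32 log units; beyond the scatter)) and to 4-methoxybenzyl (a 4.3-fold higher number from compound 3 to compound 4 (0.63 log units; beyond the scatter)), which makes compound 4 the weakest of the four in this assay. Nothing available explains this rise.

On these data alone, whether 2-methoxybenzyl on this nitrogen would give a similar rise remains open. So does the effect of a longer chain between the nitrogen and the ring, or of an amine or carboxylic acid on the ring.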